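A few compounds are considered here, and "the series" means these few. Any claim that something is new, unique, unknown or untested is made for them only; others in the source may bear on it.

Of the compounds shown here, three have been measured in a functional assay on PC-3 cells (Homo sapiens) for cytotoxicity, read by sulforhodamine B assay, with a stated time of 48 h; on this read-out lower numbers stand for stronger inhibition of growth and higher numbers for weaker inhibition of growth. Compound 1 `ClCc1ccc(Cn2cnc3c(Cl)ncnc32)cc1` gives 4780 nM. Compound 3 `ClCc1ccc(Cn2cnc3c(Cl)nc(Cl)nc32)cc1` gives 2690 nM. Compound 3 differs from compound 1 by chloro in place of hydrogen on an aromatic carbon, and the step of a 1.8-fold lower number from compound 1 to compound 3 (0.25 log units; within the scatter). Compound 2 `ClCc1cccc(Cn2cnc3ncnc(Cl)c32)c1` gives 2130 nM; the difference between its core and the core of compound 1 is not broken down here. Compound 4 `ClCc1cccc(Cn2cnc3nc(Cl)nc(Cl)c32)c1` has not yet been measured in this assay. It differs from compound 2 by chloro in place of hydrogen on an aromatic carbon, the same change as that from compound 1 to compound 3, at a place described in the same words. The step expected here is a 1.5-fold lower number from compound 2 to compound 4 (0.18 log units; within the scatter), set beside the measured 1.8-fold lower number from compound 1 to compound 3 (0.25 log units; within the scatter) on which it rests. In this assay compound 4 is therefore estimated at 1400 nM, with a likely range from 600 nM to 3200 nM.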

Compound 4, concentration for 50% growth inhibition: 1540 nM
Compound 4: middle estimate off by 1.1-fold (0.04 log units), on the low side; low and high end bracket the measured number.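

On the core of compound 2, chloro in place of hydrogen on an aromatic carbon between two ring nitrogen atoms gives a 1.4-fold lower number from compound 2 to compound 4 (0.14 log units; within the scatter) in this assay. Set beside the earlier step, the change carries across the two cores with no difference that can be told apart: the same change on two cores in this assay, a 1.8-fold lower number (0.25 log units; within the scatter) from compound 1 to compound 3 and a 1.4-fold lower number (0.14 log units; within the scatter) from compound 2 to compound 4, 1.3-fold (0.11 log units) apart, within the scatter of two such steps

Each step on its own lies within the scatter, however, so the pair shows agreement on two cores, not that this change alters growth inhibition, and it says nothing about any other core.

From the compounds shown here alone, whether an amine, a methoxy group or a longer chain on that same carbon would shift the number remains open. So does whether the agreement would hold with a hydroxymethyl group in place of the chloromethyl group.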